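This account rests on a few compounds, and the source may have more. Where it says the series, first, only, none or still open, it means among the compounds named here.

Compound 1, `COc1cc(OC)c(OC)cc1/C=C/C(=O)c1ccc(Cl)cc1`, belongs to a small set of three measured compounds that share one core and differ only in the ring attached to the carbonyl carbon. In a functional assay on SW982 cells (Homo sapiens) for inhibition, read by MTT assay, with a stated time of 72 h (a lower number here means a stronger inhibitor, a higher number a weaker inhibitor), compound 1 gives 58500 nM. Compound 2, `COc1cc(OC)c(OC)cc1/C=C/C(=O)c1cc(OC(C)=O)ccc1OC(C)=O`, gives 78500 nM, and compound 3, `COc1cc(OC)c(OC)cc1/C=C/C(=O)c1ccc(O)cc1O`, gives 32400 nM. The number for compound 1 is close to both of the others, and neither gap reaches beyond the usual scatter, so no ordering among the three can be read from these figures. Among the compounds with values here, the only single-point step on record, a 1.8-fold lower number from compound 1 to compound 3 (0.26 log units; within the scatter), is itself within the scatter.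

Compound 4, `COc1cc(OC)c(OC)cc1/C=C/C(=O)c1ccc(Br)cc1`, has not yet been measured. It differs from compound 1 by a single change: bromo in place of chloro on an aromatic carbon. Within the data shown here, none of the measured steps bears directly on this swap of one halogen for another; the step from compound 1 to compound 3 replaces the whole ring, which is a different kind of change. With nothing in the data pointing either way, no step beyond the scatter is expected in this assay. The expected step is therefore a 1.1-fold lower number from compound 1 to compound 4 (0.03 log units; within the scatter). Compound 4 is estimated to give 55000 nM, with a likely range from 25000 nM to 120000 nM.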

Compound 4, half-maximal inhibitory concentration: 38200 nM
Compound 4: middle estimate off by 1.4-fold (0.16 log units), on the high side, within the range that was stated.
By their numbers in this assay, from the lowest: compounds 3, 4, 1 and 2 (each within the scatter of the next, the first and the last beyond it).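

Exchanging one halogen for another on an aromatic carbon, para to a large group, gives a 1.5-fold lower number from compound 1 to compound 4 (0.19 log units; within the scatter) in this assay, so at this position chloro and bromo cannot be told apart in this assay. The ring-for-ring comparison gives a 1.2-fold higher number from compound 3 to compound 4 (0.07 log units; within the scatter), which means that 4-bromophenyl and 2,4-dihydroxyphenyl on the carbonyl carbon cannot be told apart here either, even though the two rings carry quite different groups. No measurement is available that could explain these small steps.

The compounds shown leave open whether a group of another kind at the place held by chloro and bromo, such as an amine, a carboxylic acid or a longer chain like butyl, would move the number by more than the usual scatter. They also leave open what a change elsewhere would do, for example replacing the methoxy groups on the shared core, since these stay the same in all four compounds and so their part in the activity cannot be judged from this set.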